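This account rests on a few compounds, and the source may have more. Where it says the series, first, only, none or still open, it means among the compounds named here.

Working notes on the series, read in a functional assay on HeLa cells (Homo sapiens) for inhibition, read by CCK-8 assay, with a stated time of 48 h; on this read-out higher numbers stand for weaker inhibition and lower numbers for stronger inhibition. Compound 1 `O=C(NCCNS(=O)(=O)c1ccc(-c2ccccc2O[C@H]2CC[C@H](O)CC2)s1)Nc1cc(C(F)(F)F)cc(C(F)(F)F)c1`, with 4-hydroxycyclohexyl on an oxygen on an aromatic ring, gives > 20000 nM, which is a limit. Compound 2 `O=C(NCCNS(=O)(=O)c1ccc(-c2ccccc2OCc2cccc(O)c2)s1)Nc1cc(C(F)(F)F)cc(C(F)(F)F)c1`, with 3-hydroxybenzyl in that place, gives 17300 nM. The step of an at least 1.1-fold lower number from compound 1 to compound 2 (0.06 log units; that floor lies within the scatter) does not separate these two.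

Compound 3 `O=C(NCCNS(=O)(=O)c1ccc(-c2ccccc2Oc2ccc([N+](=O)[O-])c([N+](=O)[O-])c2)s1)Nc1cc(C(F)(F)F)cc(C(F)(F)F)c1`, with 3,4-dinitrophenyl in that place, gives > 50000 nM, which is a limit and not a number. No measured value for it is therefore available. The step of an at least 2.8-fold higher number from compound 2 to compound 3 (0.46 log units; beyond the scatter) places it beyond the scatter on the weaker side of compound 2. The step that the two limits leave unreadable from compound 1 to compound 3 gives no order against compound 1.

Compound 4 `O=C(NCCNS(=O)(=O)c1ccc(-c2ccccc2Oc2ccc(O)c(O)c2)s1)Nc1cc(C(F)(F)F)cc(C(F)(F)F)c1` has 3,4-dihydroxyphenyl in place of 3,4-dinitrophenyl on an oxygen on an aromatic ring. Among the measured compounds shown here, no measured step makes this exact exchange. The nearest guide is compound 2, whose step an at least 2.8-fold higher number from compound 2 to compound 3 (0.46 log units; beyond the scatter) also runs between a hydroxyl-bearing aryl group and the 3,4-dinitrophenyl group. Compound 1 also bears a hydroxyl yet gives no number, so this guide is weak. A step of similar or somewhat larger size in the reverse direction is expected in this assay, seen as an at least 3.8-fold lower number from compound 3 to compound 4 (0.58 log units; beyond the scatter) in the estimate. Compound 4 is estimated at 13000 nM, with an expected range of 4000 nM to 40000 nM.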

Compound 4, half-maximal inhibitory concentration: > 20000 nM
Compound 4 ended at the assay's limit (the forecaster's own chance of this, stated with the estimate: 30%); middle value at least 1.5-fold (0.18 log units) away from the limit.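

Placing 3,4-dihydroxyphenyl in place of 3,4-dinitrophenyl on this oxygen on an aromatic ring does not yield a measured number in this assay, so the hydroxyl-bearing aryl group gives no readable gain over the dinitrophenyl compound. Among the compounds shown here, the step of an at least 1.1-fold higher number from compound 2 to compound 4 (0.06 log units; that floor lies within the scatter) does not separate the 3,4-dihydroxyphenyl group from 3-hydroxybenzyl, and the only number at this place remains that of compound 2, at 17300 nM. The steps from compound 3 to compound 4 and from compound 1 to compound 4 join two limits and cannot be read, and the limit of compound 4 is the one also held by compound 1: the limit of > 20000 nM in this assay, at which 2 of the 4 values shown sit.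

The compounds shown leave open whether any group at this place can give a number clearly stronger than that of compound 2, since three of the four readings are limits and the one number cannot set an order on its own. Also open, going by these compounds, is how a 3-aminophenyl group, a 4-carboxyphenyl group or a longer chain ending in an amine would read at this same place on the shared core.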